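A Side Group Exchange on Compound 2

This account rests on a few compounds, and the source may have more. Where it says the series, first, only, none or still open, it means among the compounds named here.

- compound 1 `COc1cc(OC)c(/C=C/S(=O)(=O)Nc2ccc(OC)c([N+](=O)[O-])c2)c(OC)c1` gives 1000 nM
- compound 2 `COC(=O)C(Nc1cc(NS(=O)(=O)/C=C/c2c(OC)cc(OC)cc2OC)ccc1OC)c1ccc(F)cc1` gives 2500 nM

Both values come from a functional assay on K562 cells (Homo sapiens) for cytotoxicity, read by trypan blue exclusion, with a stated time of 96 h; a higher number here means a weaker inhibitor, a lower number a stronger inhibitor. Compound 2 has the higher of the two numbers and lies above compound 1 by more than the usual scatter, which makes it the weaker inhibitor of this pair. Compound 3 `COc1cc(OC)c(/C=C/S(=O)(=O)Nc2ccc(OC)c(NC(C(=O)O)c3ccccc3)c2)c(OC)c1` has not yet been measured. It carries carboxy(phenyl)methyl in place of (4-fluorophenyl)(methoxycarbonyl)methyl on a nitrogen on an aromatic ring. Within the data shown here, no measured pair isolates this change, so the evidence is thin. Among the measured compounds shown here, the only guide is the lower number of compound 1 (1000 nM), and a moderate downward move is therefore expected in this assay (a 3.1-fold lower number from compound 2 to compound 3 (0.49 log units; beyond the scatter)), though a result within the scatter would not surprise. For compound 3 the estimated value is 800 nM with an expected range from 100 nM to 4000 nM (a deliberately wide estimate).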

Compound 3, half-maximal inhibitory concentration: 300 nM
Compound 3: the middle estimate sits 2.7-fold (0.43 log units) above what was measured; low and high end bracket the measured number.
By their numbers in this assay, from the lowest: compound 3; then compound 1; then compound 2.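

In this assay the nitrogen on an aromatic ring proves sensitive to what it carries: carboxy(phenyl)methyl in place of (4-fluorophenyl)(methoxycarbonyl)methyl gives an 8.3-fold lower number from compound 2 to compound 3 (0.92 log units; beyond the scatter) in a single exchange of side group. Replacing nitro on an aromatic carbon with (carboxy(phenyl)methyl)amino gives a 3.3-fold lower number from compound 1 to compound 3 (0.52 log units; beyond the scatter) and so shows that a substituted amino group here can carry a lower number than nitro, which the earlier pair did not show. No measured property of these groups is available to account for either step.

The exchange removes the fluorine and turns the methyl ester into a carboxylic acid at once, and the compounds shown do not separate these two changes. Also open, from the compounds shown here alone, is how a plain amino group on that aromatic carbon, or a longer chain bearing the carboxylic acid, would compare.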